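Single stereocentre inversion from compound 3 to compound 4

The compounds below may be only part of what the source reports. "The series", "measured", "known", "first", "only" and "open" are said of these compounds alone.

Compound 1 (`CCOC(=O)C1(C(=O)Nc2ccccc2Cl)CC1c1cc(OC)c(OC)c(OC)c1`) in a functional assay on QGY cells (Homo sapiens) for cytotoxicity, read by MTT assay, with a stated time of 48 h; a higher number here means a weaker inhibitor, a lower number a stronger inhibitor: 36100 nM; 48800 nM (2 entries)
Compound 2 (`CCOC(=O)[C@@]1(C(=O)Nc2ccccc2Cl)C[C@@H]1c1cc(OC)c(OC)c(OC)c1`): > 100000 nM (a limit)
Compound 3 (`CCOC(=O)[C@]1(C(=O)Nc2ccccc2Cl)C[C@H]1c1cc(OC)c(OC)c(OC)c1`): 28000 nM

Among the compounds with values here, compound 3 carries the only single number here, since compound 1 has two entries and compound 2 only a limit. Compound 4 (`CCOC(=O)[C@@]1(C(=O)Nc2ccccc2Cl)C[C@H]1c1cc(OC)c(OC)c(OC)c1`) keeps the atoms and bonds of compound 3 (the two compounds have the same atoms and bonds and differ only in configuration as drawn: 1 of 2 stereo elements differ; a stereocentre at a saturated ring carbon is drawn R in compound 3 and S in compound 4): a stereocentre at a saturated ring carbon is drawn R in compound 3 and S in compound 4. The nearest measured change (an at least 3.5-fold lower number from compound 2 to compound 3 (0.55 log units; beyond the scatter)) inverts both stereocentres and rests on a limit (the limit of > 100000 nM in this assay, at which 1 of the 3 values shown sits). No single inversion has been measured. Leaving the configuration of compound 3 at one centre is expected to give a modest weakening in this assay (a 1.8-fold higher number from compound 3 to compound 4 (0.25 log units; within the scatter)). Compound 4 is estimated at 50000 nM (expected range 20000 nM to 100000 nM).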

Compound 4, half-maximal inhibitory concentration: 34300 nM
Beside the measured number, compound 4's estimate is 1.5-fold (0.16 log units) above it; the measured number falls inside the stated range.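

Inverting one stereocentre alone, a change no earlier pair isolated, leaves the reading in this assay within the scatter: a 1.2-fold higher number from compound 3 to compound 4 (0.09 log units; within the scatter). Inverting the other stereocentre alone gives an at least 2.9-fold lower number from compound 2 to compound 4 (0.46 log units; beyond the scatter), so in these compounds the two centres do not count equally, and the earlier double inversion traces to this second centre. Compound 2 stands at > 100000 nM, which is a limit, so this step has only a lower bound. Open, from the compounds shown here alone, is whether a carboxylic acid in place of the ethyl ester would keep this difference between the two centres.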